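The source may hold more compounds than are shown below. What is called first, only, known or untested is meant among the compounds shown, and "the series" means these compounds.

Working notes on the series. Within the data shown here, in a functional assay on A549 cells (Homo sapiens) for inhibition, read by MTT assay, with a stated time of 72 h (on this read-out higher numbers stand for weaker inhibition and lower numbers for stronger inhibition), compound 1 `Cc1ccc(NC(=O)C2CCN(C/C=C/c3ccccc3)CC2)cc1` gives 29600 nM and compound 2 `CC(C)c1ccc(NC(=O)C2CCN(C/C=C/c3ccccc3)CC2)cc1` gives 9430 nM, the lower of the two numbers so far. Compound 3 `CCCCc1ccc(NC(=O)C2CCN(C/C=C/c3ccccc3)CC2)cc1` has not been measured. It carries butyl in place of isopropyl on an aromatic carbon, para to a large group: butyl in place of isopropyl on an aromatic carbon. Among the measured compounds shown here, only one measured step bears on this change, a 3.1-fold lower number from compound 1 to compound 2 (0.50 log units; beyond the scatter), a modest step at the same place, with isopropyl in place of methyl. That single step does not show how an unbranched chain compares with a branched one. In this assay, only a small further fall in the number is therefore expected, probably none beyond the scatter. The estimated change is a 1.3-fold lower number from compound 2 to compound 3 (0.10 log units; within the scatter). For compound 3 the expected value is 7500 nM, with an estimated range of 3000 nM to 18000 nM.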

Compound 3, half-maximal inhibitory concentration: 5910 nM
Compound 3: the middle estimate sits 1.3-fold (0.10 log units) above what was measured, and the stated range covers the measured number.
By their numbers in this assay, from the lowest: compounds 3 and 2 (each within the scatter of the next); then compound 1.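

In this assay, the unbranched butyl chain and the branched isopropyl group cannot be told apart at this position, para to a large group (a 1.6-fold lower number from compound 2 to compound 3 (0.20 log units; within the scatter)). Set against the methyl of compound 1, butyl gives a step beyond the scatter (a 5.0-fold lower number from compound 1 to compound 3 (0.70 log units; beyond the scatter)), so at this position compound 2 and compound 3 both stand apart from compound 1, while the single comparison of butyl with isopropyl shows no readable effect of branching. Nothing at hand explains these numbers.

From the compounds shown here alone, it remains open whether a chain longer than butyl, such as hexyl, or a more branched group, such as tert-butyl, would take the number further in this assay. Going by these compounds, how an amine or a carboxylic acid would behave at this same place also remains open.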